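Adding a Bromine to a Weakly Cytotoxic Bis-Chalcone

The source may hold more compounds than are shown below. What is called first, only, known or untested is meant among the compounds shown, and "the series" means these compounds.

Compound 1, `Cc1cc(O)c(C(=O)/C=C/c2ccc(Cl)cc2)c(-c2ccccc2)c1C(=O)/C=C/c1ccc(Cl)cc1`, is a core carrying two chlorine-bearing arms and a phenyl group. In a functional assay on MCF7 cells (Homo sapiens) for cytotoxicity, read by MTT assay, with a stated time of 24 h (a higher number here means a weaker inhibitor, a lower number a stronger inhibitor), compound 1 gives 10000 nM. Compound 3, `Cc1cc(O)c(C(=O)/C=C/c2ccc(OCc3ccccc3)cc2)c(-c2ccc(Br)cc2)c1C(=O)/C=C/c1ccc(OCc2ccccc2)cc1`, which carries benzyloxy-bearing arms and a 4-bromophenyl group, gives 20000 nM in this assay; this value and that of compound 1 lie within the usual scatter of each other, so the two cannot be told apart. Compound 2, `COc1ccc(/C=C/C(=O)c2c(C)cc(O)c(C(=O)/C=C/c3ccc(OC)c(OC)c3)c2-c2ccccc2)cc1OC`, with methoxy-bearing arms, is recorded in this assay as "not active" (no number reported), and no number was given for it.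

Compound 4, `Cc1cc(O)c(C(=O)/C=C/c2ccc(Cl)cc2)c(-c2ccc(Br)cc2)c1C(=O)/C=C/c1ccc(Cl)cc1`, differs from compound 1 in a single spot: bromo in place of hydrogen on an aromatic carbon, which turns the phenyl into a 4-bromophenyl. Among the measured compounds shown here, no measured pair isolates this change, but compound 3 already carries a 4-bromophenyl and still gives 20000 nM. The step of a 1.2-fold higher number from compound 1 to compound 4 (0.08 log units; within the scatter) is therefore expected to be small, no larger than the scatter, in either direction. Compound 4 is expected to give about 12000 nM in this assay, within a range from 5000 nM to 30000 nM.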

Compound 4, half-maximal inhibitory concentration: 20000 nM
The estimate for compound 4 lay 1.7-fold (0.22 log units) below the measured number; low and high end bracket the measured number.
By their numbers in this assay, from the lowest: compounds 1, 3 and 4 (each within the scatter of the next).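

Among the compounds shown here, this pair is the first in the set to differ in one place only, so the swap of hydrogen for bromo on the phenyl can be read directly. In this assay the swap gives a 2.0-fold higher number from compound 1 to compound 4 (0.30 log units; within the scatter) and so compound 1 and compound 4 cannot be told apart: with chlorine-bearing arms on the core, a bromo at this spot leaves no effect that can be separated from ordinary repeat variation. No supporting data shown here explain this outcome.

Still open, going by these compounds, is whether a different kind of group at this spot, such as an amine or a carboxylic acid, would shift the number beyond the scatter. On these data alone, it is equally open whether the same bromo swap would read alike with methoxy-bearing or benzyloxy-bearing arms on the core.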